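The compounds below may be only part of what the source reports. "The series", "measured", "known", "first", "only" and "open" are said of these compounds alone.

Three compounds have been measured in a functional assay on the whole organism (strain Lewis) with Rattus norvegicus as the target, with a stated time of 24 h, at a dose of 2 mg/kg by the oral route; a lower number here means less inhibition, a higher number more inhibition at the dose given (going by the name of the read-out):

- compound 1, `COc1ccccc1OC[C@@H]1CCc2cc([C@H]3CC[C@](N)(CO)C3)ccc2C1`, gives 85%
- compound 2, `COc1ccc(OC[C@@H]2CCc3cc([C@H]4CC[C@](N)(CO)C4)ccc3C2)cc1`, gives 47%
- compound 3, `COc1cccc(OC[C@@H]2CCc3cc([C@H]4CC[C@](N)(CO)C4)ccc3C2)c1`, gives 86%

All three share one core and differ only in where the methoxy group sits on the phenyl ring attached through an oxygen on a saturated carbon. Compound 3 has the highest number of the three, but the step of a number 1 percentage points higher from compound 1 to compound 3 (within the scatter) is within the scatter, so compound 1 and compound 3 cannot be told apart. Compound 2 is clearly lower: the step of a number 39 percentage points higher from compound 2 to compound 3 (beyond the scatter) is beyond the scatter, as is a number 38 percentage points lower from compound 1 to compound 2 (beyond the scatter).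

Compound 4, `COc1cccc(SC[C@@H]2CCc3cc([C@H]4CC[C@](N)(CO)C4)ccc3C2)c1`, keeps the 3-methoxyphenyl group of compound 3 and changes only the linking atom: (3-methoxyphenyl)sulfanyl in place of 3-methoxyphenoxy on a saturated chain carbon bound to a saturated ring carbon. Going by the values given here, none of the measured steps touches this link; all of them move the methoxy group around the ring while the oxygen link stays. Among the compounds with values here, there is therefore no measured step that directly shows what swapping oxygen for sulfur does here. With the methoxy group held in the position that gave compound 3 its value, the expectation is a step within the scatter, in no preferred direction. Compound 4 is expected to give about 78%, with a range from 50% to 95%. The estimated step of a number 8 percentage points lower from compound 3 to compound 4 (within the scatter) is expected to lie within the scatter.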

Compound 4, a percentage reported as inhibition, in the whole organism at one dose (the size of the read-out at that dose, not a potency): 81%
Compound 4: middle estimate off by 3 percentage points, on the low side; measured number inside the range.
By their numbers in this assay, from the lowest: compound 2; then compounds 4, 1 and 3 (each within the scatter of the next).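

In this assay, the oxygen of the link can be swapped for sulfur, with the 3-methoxyphenyl group kept, and the two compounds cannot be told apart (a number 5 percentage points lower from compound 3 to compound 4 (within the scatter)). Going by these compounds alone, the earlier compounds varied only the place of the methoxy group, so this is the first sign that the linking atom can change without a difference beyond the scatter; the sulfur compound also cannot be told apart from the 2-methoxyphenoxy compound (a number 4 percentage points lower from compound 1 to compound 4 (within the scatter)), while it stays well clear of the 4-methoxyphenoxy compound (a number 34 percentage points higher from compound 2 to compound 4 (beyond the scatter)). Nothing available here offers an explanation for this result.

The compounds shown leave open whether a sulfur link would give the same picture with the methoxy group in the 2-methoxyphenyl or 4-methoxyphenyl arrangement, where the oxygen series gave two very different numbers. They also leave open whether an amine nitrogen or a plain methylene carbon in place of the linking atom, or a longer chain between that atom and the shared core, would keep the read-out at this single dose.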